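Aryl swap on the vinyl sulfone arm, two cores

A few compounds are considered here, and "the series" means these few. Any claim that something is new, unique, unknown or untested is made for them only; others in the source may bear on it.

Compound 2 `O=S(=O)(/C=C/c1ccc(Cl)cc1Cl)Cc1ccc(Nc2ncnc3ccccc23)cc1` carries a 2,4-dichlorophenyl group on the double-bonded chain; in a functional assay on UACC-62 cells (Homo sapiens) (a lower number here means a stronger inhibitor of growth, a higher number a weaker inhibitor of growth), compound 2 gives 2000 nM. Compound 1 `O=S(=O)(/C=C/c1ccc(F)cc1)Cc1ccc(Nc2ncnc3ccccc23)cc1` differs from compound 2 only by 4-fluorophenyl in place of 2,4-dichlorophenyl on a double-bonded chain carbon bound to a double-bonded chain carbon. In this assay compound 1 gives 5000 nM, a step of a 2.5-fold higher number from compound 2 to compound 1 (0.40 log units; beyond the scatter), so on this core the swap costs potency by a modest but real margin.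

Compound 3 `COc1cc2ncnc(Nc3ccc(CS(=O)(=O)/C=C/c4ccc(Cl)cc4Cl)cc3)c2cc1OC` keeps the 2,4-dichlorophenyl arm on a second core; the difference between its core and the core of compound 2 is not broken down here. In this assay compound 3 gives 21000 nM, the highest number of the three measured, beyond the scatter from both compound 1 and compound 2.

Compound 4 `COc1cc2ncnc(Nc3ccc(CS(=O)(=O)/C=C/c4ccc(F)cc4)cc3)c2cc1OC` has not yet been measured. It differs from compound 3 by 4-fluorophenyl in place of 2,4-dichlorophenyl on a double-bonded chain carbon bound to a double-bonded chain carbon, the same change already made from compound 2 to compound 1, at the same place. This change occurs only twice in the set, so the expectation rests on a single measured pair.

Because that pair gave a 2.5-fold higher number from compound 2 to compound 1 (0.40 log units; beyond the scatter), the step from compound 3 to compound 4 in this assay is expected to be of similar size, about a 2.4-fold higher number from compound 3 to compound 4 (0.38 log units; beyond the scatter). Compound 4 is therefore estimated at 50000 nM in this assay. The plausible range for compound 4 is estimated to run from 15000 nM to 160000 nM. A number this high may well be reported only as a limit of the assay.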

Compound 4, concentration for 50% growth inhibition: > 100000 nM
Compound 4 was reported as a limit (the forecaster's own chance of this, stated with the estimate: 30%); at least 2.0-fold (0.30 log units) between middle value and limit.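

On the second core, the change from 2,4-dichlorophenyl to 4-fluorophenyl gives an at least 4.7-fold higher number from compound 3 to compound 4 (0.67 log units; beyond the scatter) in this assay, in the same direction as on the other core. The change therefore raises the number on both cores, but whether it costs more on one core than on the other cannot be said, and the direction rests on only one pair per core: the same change on two cores in this assay, a 2.5-fold higher number (0.40 log units; beyond the scatter) from compound 2 to compound 1 and an at least 4.7-fold higher number (0.67 log units; beyond the scatter) from compound 3 to compound 4; the limit leaves it open whether they differ Compound 4 gives > 100000 nM, which is a limit of the assay and not a number, so the true size of the step on this core stays unknown: the limit of > 100000 nM in this assay, at which 1 of the 4 values shown sits.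

Still open, from the compounds shown here alone, is how much of the step belongs to the loss of chlorine and how much to the arrival of fluorine, a question that a phenyl ring carrying a single chlorine, or an unsubstituted phenyl, on the same chain would help to separate on both cores. Also open, going by these compounds, is whether the same direction would hold for arms of a different kind at this place, such as a pyridyl ring or a phenyl ring bearing a nitrile or a carboxylic acid.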